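The compounds below may be only part of what the source reports. "The series", "measured", "known", "first", "only" and "open" are said of these compounds alone.

Compound 1 `Cc1ccc(NC(=O)/C=C/c2ccccc2)c(C(N)=O)c1`: 5500 nM
Compound 2 `NC(=O)c1cc(Br)ccc1NC(=O)/C=C/c1ccccc1`: 5000 nM
Compound 3 `NC(=O)c1cc(Cl)ccc1NC(=O)/C=C/c1ccccc1Br`: 10000 nM

In a functional assay on K562 cells (Homo sapiens) for inhibition, read by trypan blue exclusion, with a stated time of 48 h (on this read-out lower numbers stand for stronger inhibition and higher numbers for weaker inhibition), compound 3 gives 10000 nM, a number within the scatter of those for both compound 1 and compound 2. Compound 4 `Cc1ccccc1/C=C/C(=O)Nc1ccc(Cl)cc1C(N)=O` differs from compound 3 as follows: methyl in place of bromo on an aromatic carbon. This places methyl in place of bromo on an aromatic carbon. Among the measured compounds shown here, only one measured step bears on this exchange, and it runs in the opposite sense at a different site: a 1.1-fold lower number from compound 1 to compound 2 (0.04 log units; within the scatter). No step beyond the scatter is therefore expected in this assay, and no direction can be favoured. The expected change is a 1.3-fold lower number from compound 3 to compound 4 (0.10 log units; within the scatter). For compound 4 the estimated value is 8000 nM, with an expected range of 4000 nM to 16000 nM.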

Compound 4, half-maximal inhibitory concentration: 9500 nM
Compound 4: the middle estimate sits 1.2-fold (0.07 log units) below what was measured; measured number inside the range.
By their numbers in this assay, from the lowest: compounds 2, 1, 4 and 3 (each within the scatter of the next).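

In this assay, exchanging bromo for methyl on this aromatic carbon, ortho to a large group, gives a 1.1-fold lower number from compound 3 to compound 4 (0.02 log units; within the scatter). Until now the exchange had been seen only at a different site on another core, so this is its first reading at this position. The two readings agree: the same change on two cores in this assay, a 1.1-fold lower number (0.04 log units; within the scatter) from compound 1 to compound 2 and a 1.1-fold higher number (0.02 log units; within the scatter) from compound 4 to compound 3, 1.2-fold (0.06 log units) apart, within the scatter of two such steps

At this position, methyl and bromo therefore cannot be told apart in this assay. From the compounds shown here alone, what an amine or a carboxylic acid would do here remains open, including whether either would move the number beyond the scatter.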